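Removing the 3-Phenylpropyl Ester: Two Matched Steps

The source may hold more compounds than are shown below. What is called first, only, known or untested is meant among the compounds shown, and "the series" means these compounds.

Compound 2 `COc1cc(OC)cc(-c2cn(-c3ccc(O)c(C(=O)OCCCc4ccccc4)c3)nn2)c1` carries a 3-phenylpropyl ester, and in a functional assay on CCRF-CEM cells (Homo sapiens) for inhibition, read by MTT assay, with a stated time of 2 days, tested at 10 uM (a higher number here means more inhibition at the concentration tested (going by the name of the read-out), a lower number less inhibition), compound 2 gives 8%. Compound 1 `COc1cc(OC)cc(-c2cn(-c3ccc(O)c(C(=O)O)c3)nn2)c1` differs from it by hydrogen in place of 3-phenylpropyl on an oxygen next to a carbonyl group; in this assay compound 1 gives 9%, which is a number 1 percentage points higher from compound 2 to compound 1 (within the scatter). The cores of compound 2 and compound 3 `COc1ccccc1-c1cn(-c2ccc(O)c(C(=O)OCCCc3ccccc3)c2)nn1` differ by 2-methoxyphenyl in place of 3,5-dimethoxyphenyl on an aromatic carbon; in this assay compound 3 gives 4%, which is a number 4 percentage points lower from compound 2 to compound 3 (within the scatter). Compound 4 `COc1ccccc1-c1cn(-c2ccc(O)c(C(=O)O)c2)nn1` has not yet been measured. It differs from compound 3 by hydrogen in place of 3-phenylpropyl on an oxygen next to a carbonyl group, the same change at the same place as that between compound 2 and compound 1. Because that change earlier gave a number 1 percentage points higher from compound 2 to compound 1 (within the scatter), the expected step is a number 1 percentage points higher from compound 3 to compound 4 (within the scatter), a change that stays inside the usual scatter. Compound 4 is therefore estimated at 5%, likely between -5% and 15%.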

Compound 4, a percentage reported as inhibition, at one concentration (the size of the read-out at that concentration, not a potency): 9%
For compound 4 the middle estimate is 4 percentage points below the measured one; low and high end bracket the measured number.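

In this assay, hydrogen in place of 3-phenylpropyl on an oxygen next to a carbonyl group gives a number 5 percentage points higher from compound 3 to compound 4 (within the scatter). Set beside the earlier step, the change reads the same on both cores within the scatter: the same change on two cores in this assay, a number 1 percentage points higher (within the scatter) from compound 2 to compound 1 and a number 5 percentage points higher (within the scatter) from compound 3 to compound 4, 4 percentage points apart, within the scatter of two such steps. This does not show that the change has any effect on either core, as each step stays within the scatter, and two cores at a single concentration give no rule for the wider series.

The compounds shown leave open whether a methyl ester, a longer chain or an amide at this place would read the same way. They also leave open cores carrying an amine in place of the methoxy groups.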